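A few compounds are considered here, and "the series" means these few. Any claim that something is new, unique, unknown or untested is made for them only; others in the source may bear on it.

Measured so far:
compound 1 `CC[C@H](C)[C@H](NC(=O)c1cccc(Cn2ccnc2)c1)C(=O)Nc1nccs1`: 4%
compound 2 `CCCCS(=O)(=O)NC(=O)[C@@H](NC(=O)c1cccc(Cn2ccnc2)c1)[C@@H](C)CC`: "not determined" (no result reported)
compound 3 `CC[C@H](C)[C@H](NC(=O)c1cccc(Cn2ccnc2)c1)C(=O)NNS(=O)(=O)c1ccc(OC)cc1`: 3%

In an assay on HEK293 cells for displacement of a labelled ligand from Type-2 angiotensin II receptor (Homo sapiens), tested at 1 uM (on this read-out lower numbers stand for a weaker effect and higher numbers for a stronger effect at the one concentration tested), compound 1 gives 4% and compound 3 gives 3%; the two values lie within the scatter of each other. For compound 2 no result has been reported, so it stands nowhere on the numbers shown. Compound 4 `CC[C@H](C)[C@H](NC(=O)c1cccc(Cn2ccnc2)c1)C(=O)NC#N` is the next candidate; it is derived from compound 2 by cyano in place of butylsulfonyl on an amide-type nitrogen. With no number for compound 2, neither size nor direction of the step in this assay can be read from that pair. Compound 1 with 4% and compound 3 with 3% both come out low, and the expectation for compound 4 follows them. Compound 4 is expected to give 5%, within 0% to 15%.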

Compound 4, a percentage reported as inhibition, at one concentration (the size of the read-out at that concentration, not a potency): 6%
Estimate against measurement, compound 4: 1 percentage points below, and the stated range covers the measured number.
By their numbers in this assay, from the lowest: compounds 3, 1 and 4 (each within the scatter of the next).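

With cyano on the amide-type nitrogen, this assay gives a number 2 percentage points higher from compound 1 to compound 4 (within the scatter) so cyano and 1,3-thiazol-2-yl cannot be told apart at this position, despite the different groups. The step from butylsulfonyl to cyano cannot be read: compound 2 has no reported result. No evidence bearing on this result is available.

Still open, from the compounds shown here alone, is whether a carboxylic acid, an amine or a longer alkyl chain on this nitrogen would give a higher read-out. Also open, going by these compounds, is whether changes elsewhere on the shared core would do so.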